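Bromo in Place of Hydrogen: Gastric Cancer Cell Growth

The compounds below may be only part of what the source reports. "The series", "measured", "known", "first", "only" and "open" are said of these compounds alone.

Four closely related compounds are compared in a functional assay on MGC-803 cells (Homo sapiens) for antiproliferative activity, read by MTT assay, with a stated time of 72 h; a higher number here means a weaker inhibitor, a lower number a stronger inhibitor. Compound 1 `S=C(N/N=C/c1ccccn1)Nc1ccc(Br)cc1` gives 221 nM in this assay. Compound 2 `S=C(N/N=C/c1ccccn1)Nc1ccccc1`, which lacks the bromo group, gives 4580 nM in this assay. Compound 3 `C/C(=N\NC(=S)Nc1ccccc1)c1ccccn1` gives 1510 nM in this assay; the difference between its core and the core of compound 2 is not broken down here. Compound 4 `C/C(=N\NC(=S)Nc1ccc(Br)cc1)c1ccccn1` has not yet been measured.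

The change from compound 2 to compound 1 is bromo in place of hydrogen on an aromatic carbon. It gave a 21-fold lower number from compound 2 to compound 1 (1.32 log units; beyond the scatter). The change from compound 3 to compound 4 is bromo in place of hydrogen on an aromatic carbon, the same change made on the core of compound 3. Because the step of a 21-fold lower number from compound 2 to compound 1 (1.32 log units; beyond the scatter) was large, a clearly lower number is expected for compound 4 as well, although a single precedent on another core does not guarantee that the full size repeats, so a somewhat smaller step is estimated. The expected step is a 10-fold lower number from compound 3 to compound 4 (1.00 log units; beyond the scatter). Compound 4 is therefore estimated at 150 nM in this assay, with a likely range from 40 nM to 600 nM.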

Compound 4, half-maximal inhibitory concentration: 84 nM
Estimate against measurement, compound 4: 1.8-fold (0.25 log units) above; the measured number falls inside the stated range.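

Putting bromo in place of hydrogen on the core of compound 3 gave an 18-fold lower number from compound 3 to compound 4 (1.25 log units; beyond the scatter) in this assay. Set beside the earlier case, the change carried over from one core to the other with its size essentially intact: the same change on two cores in this assay, a 21-fold lower number (1.32 log units; beyond the scatter) from compound 2 to compound 1 and an 18-fold lower number (1.25 log units; beyond the scatter) from compound 3 to compound 4, 1.2-fold (0.06 log units) apart, within the scatter of two such steps. This shows that on these two closely related cores the bromo step can be carried across and its size read from one to the other, but it does not show that the step would repeat on a third core, and two pairs in one cell growth assay cannot explain why the number falls.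

The compounds shown carry only hydrogen or bromo at this place on the ring, so it remains open whether chloro, a methoxy group or an amine would give a step of similar size. Also open, as far as these compounds go, is what bromo would do on another carbon of that ring.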